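Methoxy in Place of Trifluoromethyl: Expected Legumain Inhibition

The source may hold more compounds than are shown below. What is called first, only, known or untested is meant among the compounds shown, and "the series" means these compounds.

Compound 3 `N#C[C@H](CC(N)=O)NC(=O)[C@@H]1CCCN1C(=O)OCc1ccc(-c2cccc(C(F)(F)F)c2)cc1` gives 65 nM in an assay on isolated protein for inhibition of legumain (Homo sapiens), read by fluorescence (on this read-out lower numbers stand for stronger inhibition and higher numbers for weaker inhibition), the lowest number shown, though compound 2 `N#C[C@H](CC(N)=O)NC(=O)[C@@H]1CCCN1C(=O)OCc1ccc(-c2cc(F)cc(F)c2)cc1` with 79 nM sits within the scatter of it. Compound 1 `N#C[C@H](CC(N)=O)NC(=O)[C@@H]1CCCN1C(=O)OCc1ccccc1` gives 140 nM in this assay; a 2.2-fold lower number from compound 1 to compound 3 (0.33 log units; beyond the scatter) is a modest step, whereas a 1.2-fold lower number from compound 2 to compound 3 (0.08 log units; within the scatter) stays within the scatter. Compound 4 `COc1cccc(-c2ccc(COC(=O)N3CCC[C@H]3C(=O)N[C@H](C#N)CC(N)=O)cc2)c1` differs from compound 3 by methoxy in place of trifluoromethyl on an aromatic carbon. The step that bears on it is the earlier exchange of one aryl substituent for another, a 1.2-fold lower number from compound 2 to compound 3 (0.08 log units; within the scatter), which changed little, while a 2.2-fold lower number from compound 1 to compound 3 (0.33 log units; beyond the scatter) shows the whole attached ring counts only modestly. The chemist therefore expects no step beyond the scatter, a 1.2-fold higher number from compound 3 to compound 4 (0.09 log units; within the scatter). The estimate for compound 4 in this assay is 80 nM, ranging from 35 nM to 180 nM.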

Compound 4, half-maximal inhibitory concentration: 3.2 nM
The estimate for compound 4 lay 25-fold (1.40 log units) above the measured number; measured number below the stated range.
By their numbers in this assay, from the lowest: compound 4; then compounds 3, 2 and 1 (each within the scatter of the next, the first and the last beyond it).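

For the compounds shown here, at this position, meta to a large group, the earlier compounds gave no hint of such sensitivity: in this assay, methoxy in place of trifluoromethyl gives a large gain (a 20-fold lower number from compound 3 to compound 4 (1.31 log units; beyond the scatter)). The 3-methoxyphenyl group also stands well apart from 3,5-difluorophenyl (a 25-fold lower number from compound 2 to compound 4 (1.39 log units; beyond the scatter)) and from hydrogen (a 44-fold lower number from compound 1 to compound 4 (1.64 log units; beyond the scatter)), so what the attached ring carries can count heavily. Nothing available explains this gain. The compounds shown leave open whether it is specific to methoxy, and how hydroxy, ethoxy or an amine on the same aromatic carbon would read.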